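Notes on amino substitution in compound 2

The compounds below may be only part of what the source reports. "The series", "measured", "known", "first", "only" and "open" are said of these compounds alone.

Measured so far in a toxicity assay on NIH3T3 cells (Mus musculus) for cytotoxicity, read by resazurin assay; on this read-out higher numbers stand for an effect only at larger amounts of compound and lower numbers for an effect already at smaller amounts (both values are limits, not numbers):
- compound 1 `CNC(=O)c1ccc(NCc2cncn2Cc2ccc(-c3ccccc3)cc2N)cc1-c1ccccc1` gives > 1000 nM as a limit
- compound 2 `COC(=O)c1ccc(NCc2cncn2Cc2ccccc2)cc1-c1ccccc1` gives > 1000 nM as a limit

Compound 2 stands at > 1000 nM in this assay as a limit, with no number. Compound 3 `COC(=O)c1ccc(NCc2cncn2Cc2ccccc2N)cc1-c1ccccc1` carries amino in place of hydrogen on an aromatic carbon, ortho to a large group amino in place of hydrogen on an aromatic carbon and so turns benzyl to 2-aminobenzyl. Going by the values given here, no step between measured compounds exists, and the expected change is a step that the limit leaves unreadable from compound 2 to compound 3 within the scatter, in no clear direction. The expectation rests on the limit of > 1000 nM in this assay, at which 2 of the 2 values shown sit, alone. Compound 3 is expected at 1200 nM with an estimated range from 400 nM to 5000 nM in this read-out.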

Compound 3, half-maximal effective concentration: 25000 nM
Beside the measured number, compound 3's estimate is 21-fold (1.32 log units) below it; measured number outside the range, above it.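

No step can be read from compound 2 to compound 3: the value of compound 2 is a limit, not a number. From the compounds shown here alone, whether amino in place of hydrogen shifts this assay, and in which direction, stays open.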